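The source may report more compounds than this note shows. Statements on the series, on what has been measured and on what is new or still open speak of the compounds shown alone.

Of the compounds shown here, three built on a shared core have been measured in a physicochemical assay for lipophilicity, read by HPLC; on this read-out higher numbers stand for higher lipophilicity and lower numbers for lower lipophilicity. In this assay compound 1 `Cc1ccsc1C(=CCCN(C)C(CO)C(=O)NCc1ccccc1)c1sccc1C` gives 6.26. Compound 2 `Cc1ccsc1C(=CCCN(C)C(CCN)C(=O)NCc1ccccc1)c1sccc1C` differs from compound 1 by aminomethyl in place of hydroxy on a saturated chain carbon, two bonds along the chain from an amine nitrogen and a carbonyl carbon, and in this assay compound 2 gives 5.5. This single change produced a step of a number 0.76 log units lower from compound 1 to compound 2 (beyond the scatter). Compound 3 `Cc1ccsc1C(=CCCN(C)C(CO)C(=O)NCc1ccc(F)cc1)c1sccc1C` is the third measured compound; in this assay compound 3 gives 6.45, which lies a number 0.19 log units higher from compound 1 to compound 3 (within the scatter).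

Compound 4 `Cc1ccsc1C(=CCCN(C)C(CCN)C(=O)NCc1ccc(F)cc1)c1sccc1C` has not yet been measured. It differs from compound 3 by aminomethyl in place of hydroxy on a saturated chain carbon, two bonds along the chain from an amine nitrogen and a carbonyl carbon. Within the data shown here, this is the same change, at the same place on the chain, that turned compound 1 into compound 2; the only way the two pairs differ is in their cores, and the core of compound 3 differs from the core of compound 1 by fluoro in place of hydrogen on an aromatic carbon.

Since that earlier swap gave a step of a number 0.76 log units lower from compound 1 to compound 2 (beyond the scatter), a step of about the same size is expected here, namely a number 0.76 log units lower from compound 3 to compound 4 (beyond the scatter). Compound 4 is therefore estimated to give 5.69 in this assay. Allowing for the usual scatter of such measurements, compound 4 is expected to fall between 5.3 and 6.1. Whether the change in the core alters the size of the step remains to be seen once the value is known.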

Compound 4, partition coefficient: 6.45
The estimate for compound 4 lay 0.76 log units below the measured number; measured number above the stated range.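

On the core of compound 1, aminomethyl in place of hydroxy gave a number 0.76 log units lower from compound 1 to compound 2 (beyond the scatter) in this assay, but on the core of compound 3 the same swap gave no change at the digits printed from compound 3 to compound 4 (within the scatter) in that read-out, so the step did not carry over from one core to the other. The pairs that share the fluoro change tell the same story from the other side: with hydroxy on the chain it gave a number 0.19 log units higher from compound 1 to compound 3 (within the scatter) as its step, whereas with aminomethyl it gave a number 0.95 log units higher from compound 2 to compound 4 (beyond the scatter) as its step, so in these four compounds the effects of the two changes do not simply add up. This rests on a single comparison of two pairs and does not show how the swap would behave on any other core, and no measurement at hand speaks to why the two steps differ.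

The compounds shown leave open whether a carboxylic acid or a longer amine chain at the same place on the chain would also depend on the core in this way. They also leave open whether chloro in place of fluoro on the aromatic carbon would alter the step as fluoro did.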